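Dropping the Methyl from the Anilide of Compound 3

The compounds below may be only part of what the source reports. "The series", "measured", "known", "first", "only" and "open" are said of these compounds alone.

Compound 3 `C=CC1=C(C(=O)Nc2cccc(C)c2)C(c2ccc(F)cc2)OC1` belongs to a small set in which every result so far is a limit of the assay. In a functional assay on A549 cells (Homo sapiens) for cytotoxicity, read by MTT assay, with a stated time of 24 h (a lower number here means a stronger inhibitor, a higher number a weaker inhibitor), compound 3 gives > 100000 nM, which is a limit. Compound 1 `C=CC1=C(C(=O)NCc2ccc(Cl)cc2)C(c2ccc(OC)c(OC)c2)OC1` gives > 100000 nM in this assay, also a limit. Compound 2 `C=CC1=C(C(=O)Nc2ccc(C)cc2)C(c2ccc(F)cc2)OC1` gives > 100000 nM in this assay, again a limit. The only single change among the measured compounds, a step that the two limits leave unreadable from compound 2 to compound 3, therefore cannot be sized; all three values sit at the limit of > 100000 nM in this assay, at which 3 of the 3 values shown sit, and compound 3 stands with them, at the limit, neither stronger nor weaker than its neighbours on the numbers shown.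

Compound 4 `C=CC1=C(C(=O)Nc2ccccc2)C(c2ccc(F)cc2)OC1` differs from compound 3 by hydrogen in place of methyl on an aromatic carbon. Among the compounds with values here, no measured step bears directly on this change: the one step in the set, a step that the two limits leave unreadable from compound 2 to compound 3, moves the methyl rather than removing it and is itself unreadable. With every value sitting at the limit of > 100000 nM in this assay, at which 3 of the 3 values shown sit, there is no sign of a direction, and the expectation is that the step that the limit leaves unreadable from compound 3 to compound 4 stays within the scatter. Compound 4 is therefore estimated at 150000 nM in this assay, expected between 50000 nM and 500000 nM, and most likely reported once more only as a limit.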

Compound 4, half-maximal inhibitory concentration: > 100000 nM
Compound 4: only a limit was reported; the forecaster's own chance of this, stated with the estimate: 85%; the middle value does not contradict the limit.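

In this assay compound 4 gives > 100000 nM and this value, too, is a limit. No new step can be read, neither from compound 2 nor from compound 3 to compound 4, since all the values share one limit: the limit of > 100000 nM in this assay, at which 4 of the 4 values shown sit.

The compounds shown leave open how far each lies from that limit, and whether any change to them would give a measurable value in this assay.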